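Para-substituent series on the thiazolylimino thiadiazole scaffold

A few compounds are considered here, and "the series" means these few. Any claim that something is new, unique, unknown or untested is made for them only; others in the source may bear on it.

Measured compounds:
compound 1, `Cc1c(-c2csc(NC(=S)Nc3ccccc3)n2)c(=O)n(-c2ccccc2)n1C` — 7740 nM
compound 2, `CC(=O)c1nn(-c2ccccc2)/c(=N/c2nc(-c3c(C)n(C)n(-c4ccccc4)c3=O)cs2)s1` — > 100000 nM
compound 3, `CC(=O)c1nn(-c2ccc(C)cc2)/c(=N/c2nc(-c3c(C)n(C)n(-c4ccccc4)c3=O)cs2)s1` — 20700 nM

In a functional assay on A549 cells (Homo sapiens) for cytotoxicity, read by sulforhodamine B assay, with a stated time of 72 h (a higher number here means a weaker inhibitor, a lower number a stronger inhibitor), compound 1 gives 7740 nM. Compound 2 reaches only the limit of the assay, > 100000 nM, and no number is known for it. Within the data shown here, compound 3 gives 20700 nM in this assay, which is the highest of the two numbers known; the nearest, compound 1, sits a step away that is beyond the scatter. One further value, that of compound 2, is a limit (the limit of > 100000 nM in this assay, at which 1 of the 3 values shown sits).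

Among the measured compounds shown here, the single step between measured compounds that differ in one place is an at least 4.8-fold lower number from compound 2 to compound 3 (0.68 log units; beyond the scatter), methyl in place of hydrogen on an aromatic carbon of the phenyl on the thiadiazole nitrogen. Compound 4, `CC(=O)c1nn(-c2ccc([N+](=O)[O-])cc2)/c(=N/c2nc(-c3c(C)n(C)n(-c4ccccc4)c3=O)cs2)s1`, continues on that same ring: nitro in place of methyl on an aromatic carbon. For the measured compounds named here, this change touches the position that the measured step already probed, so that step is the only evidence bearing on it, but it tells what adding a methyl did, not what a nitro does in its place. Nothing here separates one substituent from another at that site.

For compound 4 in this assay the expectation is therefore a value near compound 3, 20000 nM (range 5000 nM to 80000 nM), with the step of a 1.0-fold lower number from compound 3 to compound 4 (0.01 log units; within the scatter) expected to lie within the scatter and the range kept broad because compound 2 reached only the limit.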

Compound 4, half-maximal inhibitory concentration: > 100000 nM
Compound 4 ended at the assay's limit; the forecaster's own chance of this, stated with the estimate: 20%; middle value at least 5.0-fold (0.69 log units) away from the limit.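

In this assay, among these compounds, the change from 4-methylphenyl to 4-nitrophenyl gives an at least 4.8-fold higher number from compound 3 to compound 4 (0.68 log units; beyond the scatter), so the substituent on this aromatic carbon, para to a large group, does affect the read-out, something the single earlier step could not show. Compound 4 gives > 100000 nM, which is a limit of the assay and not a number. Of the three groups compared at this site, only 4-methylphenyl gives a readable number, and the step from compound 2 to compound 4 cannot be read, so the unsubstituted phenyl and 4-nitrophenyl cannot be ordered against each other: the limit of > 100000 nM in this assay, at which 2 of the 4 values shown sit.

On these data alone, whether an amine, a methoxy group or a longer alkyl chain on this carbon would also give a readable number, and whether any such group would pass compound 3, stays open. As far as these compounds go, the full size of the two readable steps at this site also stays open, as both end at a compound without a number.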